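Changing the Group on the Ring Nitrogen

The source may hold more compounds than are shown below. What is called first, only, known or untested is meant among the compounds shown, and "the series" means these compounds.

Compound 1 `Cc1ccc(-n2nc(-c3ccc(C(F)(F)F)cc3O)nc2-c2ccccc2O)cc1` gives 71.5% in a functional assay on PC-12 cells (Rattus norvegicus) for cytotoxicity, read by MTT assay, with stated times of 2 h and 24 h, tested at 1 uM; on this read-out higher numbers stand for a stronger effect at the one concentration tested and lower numbers for a weaker effect. Compound 2 `CC(C)(C)c1ccc(-n2nc(-c3ccc(C(F)(F)F)cc3O)nc2-c2ccccc2O)cc1` gives 67.3% in this assay; the step of a number 4.2 percentage points lower from compound 1 to compound 2 (within the scatter), so on the numbers shown compound 2 sits alongside compound 1, the gap between them lying within the scatter. Compound 3 `COc1ccccc1-n1nc(-c2ccc(C(F)(F)F)cc2O)nc1-c1ccccc1O` differs from compound 2 by 2-methoxyphenyl in place of 4-(tert-butyl)phenyl on an aromatic nitrogen. Going by the values given here, no measured step covers this change; the only step known, a number 4.2 percentage points lower from compound 1 to compound 2 (within the scatter), also swapped a group on an aromatic nitrogen without a shift beyond the scatter, so a step of a number 2.3 percentage points lower from compound 2 to compound 3 (within the scatter) is expected, with no clear direction. Compound 3 is therefore estimated at 65%, within 45% to 80%.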

Compound 3, a percentage reported as activity, at one concentration (the size of the read-out at that concentration, not a potency): 70.7%
Compound 3: the middle estimate sits 5.7 percentage points below what was measured; the measured number falls inside the stated range.
By their numbers in this assay, from the lowest: compounds 2, 3 and 1 (each within the scatter of the next).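

Swapping in 2-methoxyphenyl puts an oxygen-bearing group on this aromatic nitrogen, yet in this assay the outcome is a number 3.4 percentage points higher from compound 2 to compound 3 (within the scatter) and, against the other comparison, a number 0.8 percentage points lower from compound 1 to compound 3 (within the scatter). Compounds 1, 2 and 3 thus show that this nitrogen can carry 4-methylphenyl, 4-(tert-butyl)phenyl or 2-methoxyphenyl without the read-out moving beyond the scatter. No supporting measurement explains this. From the compounds shown here alone, whether a phenyl ring bearing a carboxylic acid or an amine would shift the number remains open. So does whether a simple ethyl chain could replace the ring here.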